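A few compounds are considered here, and "the series" means these few. Any claim that something is new, unique, unknown or untested is made for them only; others in the source may bear on it.

Compound 1 `COc1ccc([C@H]2CC(=O)N(Cc3cccc([N+](=O)[O-])c3)C2)cc1OC1CCCC1` is tested in a functional assay on HEK293 cells (Homo sapiens) for cytotoxicity (a higher number here means that more compound is tolerated, a lower number that less compound is tolerated), where compound 1 gives > 10000 nM, a limit of the assay rather than a number. Compound 2 `COc1ccc([C@H]2CC(=O)N(C(=O)c3ccccc3)C2)cc1OC1CCCC1` in this assay gives > 10000 nM, also a limit. The step that the two limits leave unreadable from compound 1 to compound 2 is therefore unreadable. Compound 3 `COc1ccc([C@H]2CC(=O)N(c3ccccc3N)C2)cc1OC1CCCC1` differs from compound 1 in one place: 2-aminophenyl in place of 3-nitrobenzyl on an amide-type nitrogen in a ring. Going by the values given here, both measured values sit at the same limit (the limit of > 10000 nM in this assay, at which 2 of the 2 values shown sit), so no measured step gives a direction for this change, and no step beyond the scatter is expected. Compound 3 is expected to give 10000 nM, between 3000 nM and 30000 nM. This estimate means an expected step of a number no higher from compound 1 to compound 3 (the limit leaves the size open).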

Compound 3, half-maximal cytotoxic concentration: > 10000 nM
Compound 3: no number, only a limit; the forecaster's own chance of this, stated with the estimate: 75%; the middle value sits exactly at the limit.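

No step can be read among compound 1, compound 2 and compound 3, because each result in this assay is a limit of the assay: the limit of > 10000 nM in this assay, at which 3 of the 3 values shown sit. The compounds shown leave open whether these three groups on the amide-type nitrogen differ at all in how much compound the cells tolerate.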